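Trading methoxy for cyano on the shared core

The source may hold more compounds than are shown below. What is called first, only, known or untested is meant among the compounds shown, and "the series" means these compounds.

Two compounds measured in a functional assay on MCF7 cells (Homo sapiens) for cytotoxicity, read by CellTiter-Glo, with a stated time of 5 days (a higher number here means a weaker inhibitor, a lower number a stronger inhibitor), set the scale. Compound 1 `CC/C(=C(/c1ccc(/C=C/C(=O)O)cc1)c1ccc2[nH]ncc2c1Cl)c1ccccc1` gives 1.6 nM, and compound 2 `CC/C(=C(/c1ccc(/C=C/C(=O)O)cc1)c1ccc2[nH]ncc2c1OC)c1ccccc1` gives 55 nM, the higher of the two numbers. Among the measured compounds shown here, the single step known, a 34-fold higher number from compound 1 to compound 2 (1.54 log units; beyond the scatter), shows that the group at this position matters greatly. Compound 3 `CC/C(=C(/c1ccc(/C=C/C(=O)O)cc1)c1ccc2[nH]ncc2c1C#N)c1ccccc1` carries cyano in place of methoxy on an aromatic carbon. For the measured compounds named here, no measured step involves cyano, so the size of this step is uncertain. Compound 3 is nevertheless expected to move back toward lower numbers, a 5.5-fold lower number from compound 2 to compound 3 (0.74 log units; beyond the scatter). Compound 3 is estimated at 10 nM, within 2 nM to 50 nM.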

Compound 3, half-maximal inhibitory concentration: 1.5 nM
Beside the measured number, compound 3's estimate is 6.7-fold (0.82 log units) above it; measured number below the stated range.
By their numbers in this assay, from the lowest: compounds 3 and 1 (each within the scatter of the next); then compound 2.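

In this assay, the change to cyano does more than partly recover the loss seen with methoxy: a 37-fold lower number from compound 2 to compound 3 (1.56 log units; beyond the scatter) matches the size of the earlier step, and a 1.1-fold lower number from compound 1 to compound 3 (0.03 log units; within the scatter) places cyano level with chloro. Of the three groups at this position, methoxy alone stands apart with a higher number. Nothing measured here accounts for this difference between the groups. From the compounds shown here alone, whether a fluoro group, a methyl group or an amine at this position would side with chloro and cyano or with methoxy remains open.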